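From 4-fluorophenyl to 2-methylphenyl on a selenium

This account rests on a few compounds, and the source may have more. Where it says the series, first, only, none or still open, it means among the compounds named here.

Values in a functional assay on SK-MEL-147 cells (Homo sapiens) for cytotoxicity, read by MTT assay, with a stated time of 24 h; on this read-out higher numbers stand for an effect only at larger amounts of compound and lower numbers for an effect already at smaller amounts:
Compound 1 `CCOC(=O)c1cc([Se]c2ccc(F)cc2)c2cc(OC)ccc2n1`: > 150000 nM (a limit)
Compound 2 `CCOC(=O)c1cc([Se]c2ccccc2)c2cc(Cl)ccc2n1`: 47100 nM
Compound 3 `COc1ccc2nc(-c3cccs3)cc([Se]c3ccccc3)c2c1`: > 150000 nM (a limit)

Compound 1 stands at a limit of the assay, not at a number: compound 1 gives > 150000 nM. This is the limit of > 150000 nM in this assay, at which 2 of the 3 values shown sit.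

Compound 4 `CCOC(=O)c1cc([Se]c2ccccc2C)c2cc(OC)ccc2n1` is still unmeasured. It differs from compound 1 by one change, (2-methylphenyl in place of 4-fluorophenyl on a selenium), with 2-methylphenyl in place of 4-fluorophenyl on a selenium. Among the compounds with values here, no measured pair of compounds shows a step of this kind. In this assay the expected move is small and toward smaller amounts, an at least 1.2-fold lower number from compound 1 to compound 4 (0.09 log units; that floor lies within the scatter). The low end of the estimate is set with compound 2 in view, at 47100 nM. Compound 4 is estimated at 120000 nM, with an expected range from 45000 nM to 300000 nM.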

Compound 4, half-maximal effective concentration: 38900 nM
The estimate for compound 4 lay 3.1-fold (0.49 log units) above the measured number, outside the stated range (below it).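

In this assay, the group on the selenium turns out to matter on this core: 2-methylphenyl in place of 4-fluorophenyl gives an at least 3.8-fold lower number from compound 1 to compound 4 (0.58 log units; beyond the scatter). Compound 4 thus reaches a measurable number on the methoxy-bearing core of compound 1. Compound 1 itself gives only a limit, so this step is a floor and its full size stays unknown: the limit of > 150000 nM in this assay, at which 2 of the 4 values shown sit.

The compounds shown leave open whether gaining the methyl or losing the fluorine carries the step. They also leave open how an aminophenyl group or a longer alkyl chain on the selenium would read.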